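The compounds below may be only part of what the source reports. "The series", "measured", "known", "first", "only" and "open" are said of these compounds alone.

Measured so far in an assay on Sf9 cells for inhibition of Amine oxidase [flavin-containing] B (Homo sapiens), with stated times of 15 min and 60 min; on this read-out higher numbers stand for weaker inhibition and lower numbers for stronger inhibition:
compound 1 `NC(=O)C1CCN1Cc1ccc(OCc2cccc(F)c2)cc1` gives 46 nM
compound 2 `NC(=O)[C@@H]1CCN1Cc1ccc(OCc2cccc(F)c2)cc1` gives 21 nM

Going by the values given here, compound 2 holds the lowest of the two numbers, the only step being a 2.2-fold lower number from compound 1 to compound 2 (0.34 log units; beyond the scatter); that pair differs solely in the fact that one of compounds 1 and 2 is drawn with a defined configuration and the other without, at the place where they differ. Compound 3 `NC(=O)[C@@H]1CCCN1Cc1ccc(OCc2cccc(F)c2)cc1` brings (2-carbamoylpyrrolidin-1-yl in place of 2-carbamoylazetidin-1-yl on a saturated chain carbon bound to an aromatic carbon). Among the compounds with values here, no measured step changes the ring size of this group; the one step known, a 2.2-fold lower number from compound 1 to compound 2 (0.34 log units; beyond the scatter), concerns drawn configuration only and gives no guide to a ring expansion, so no step beyond the scatter is assumed. Compound 3 is expected to give 21 nM in this assay, with a range of 7 nM to 63 nM. The expected step is therefore no change at the digits printed from compound 2 to compound 3 (within the scatter), a rough estimate.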

Compound 3, half-maximal inhibitory concentration: 204 nM
Estimate against measurement, compound 3: 9.7-fold (0.99 log units) below; the whole stated range lies below it.
By their numbers in this assay, from the lowest: compound 2; then compound 1; then compound 3.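

In this assay, the ring size at this place counts: on a saturated chain carbon bound to an aromatic carbon, 2-carbamoylpyrrolidin-1-yl in place of 2-carbamoylazetidin-1-yl gives a 9.7-fold higher number from compound 2 to compound 3 (0.99 log units; beyond the scatter). The same change read against the compound without a drawn configuration gives a 4.4-fold higher number from compound 1 to compound 3 (0.65 log units; beyond the scatter), so the loss does not depend on which of the two four-membered compounds serves as reference. Nothing measured here accounts for this ring-size effect.

Still open, going by these compounds, is how the opposite configuration of the 2-carbamoylpyrrolidin-1-yl group would read. Also open, on these data alone, is whether a carboxylic acid or a simple amine could stand in place of the carbamoyl group on either ring.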